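The compounds below may be only part of what the source reports. "The series", "measured", "known", "first", "only" and "open" are said of these compounds alone.

Compound 1 `O=C1c2c[n+]([O-])c3ccccc3c2C(=O)c2c1c1ccccc1n2CCCCn1ccnc1` gives 240 nM in a functional assay on HCT-116 cells (Homo sapiens) for cytotoxicity, read by MTT assay, with a stated time of 72 h; a higher number here means a weaker inhibitor, a lower number a stronger inhibitor.
Compound 2 `CCCN1CCN(CCCCn2c3c(c4ccccc42)C(=O)c2c[n+]([O-])c4ccccc4c2C3=O)CC1` gives 790 nM in this assay.

For the measured compounds named here, of these two numbers, compound 2 carries the higher one; the single measured step, a 3.3-fold higher number from compound 1 to compound 2 (0.52 log units; beyond the scatter), sets it apart from compound 1. Compound 3 `CN1CCN(CCCCCn2c3c(c4ccccc42)C(=O)c2c[n+]([O-])c4ccccc4c2C3=O)CC1` has not yet been measured. It differs from compound 2 in one place: (4-methylpiperazin-1-yl)methyl in place of 4-propylpiperazin-1-yl on a saturated chain carbon, four bonds along the chain from an aromatic nitrogen. Going by the values given here, the measured step exchanged one whole group for a quite different one, whereas this change keeps the same kind of ring, a six-membered non-aromatic ring with 2 hetero atoms, and only redistributes the carbons around it, so no measured step bears directly on it. With nothing pointing either way, the expected step is one no larger than the scatter, a 1.1-fold lower number from compound 2 to compound 3 (0.05 log units; within the scatter). Compound 3 is therefore estimated to give about 700 nM in this assay, within a range from 280 nM to 1800 nM.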

Compound 3, half-maximal inhibitory concentration: 1220 nM
Estimate against measurement, compound 3: 1.7-fold (0.24 log units) below, within the range that was stated.
By their numbers in this assay, from the lowest: compound 1; then compounds 2 and 3 (each within the scatter of the next).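

The exchange of 4-propylpiperazin-1-yl for (4-methylpiperazin-1-yl)methyl gives a 1.5-fold higher number from compound 2 to compound 3 (0.19 log units; within the scatter), so in this assay redistributing the carbons around the same kind of ring does not separate these two compounds. The other new step, a 5.1-fold higher number from compound 1 to compound 3 (0.71 log units; beyond the scatter), shows that a second piperazine-bearing group also stands apart from the 1H-imidazol-1-yl group of compound 1, so the gap at this position is not tied to 4-propylpiperazin-1-yl alone. Nothing available explains these numbers.

On these data alone, it remains open whether another ring or amine, such as morpholin-4-yl or dimethylamino, on the same saturated chain carbon would fall near compound 1 or near compounds 2 and 3. As far as these compounds go, the effect of a longer chain carrying the 1H-imidazol-1-yl group also remains open.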